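A Small Alcohol Replaces the Sulfonamide Group

The source may hold more compounds than are shown below. What is called first, only, known or untested is meant among the compounds shown, and "the series" means these compounds.

Three measured compounds share one core and differ in the group on an aromatic carbon. In a functional assay on MCF7 cells (Homo sapiens) for antiproliferative activity, read by MTT assay, with a stated time of 72 h (on this read-out lower numbers stand for stronger inhibition and higher numbers for weaker inhibition), compound 1 (`O=C1O[C@H]([C@@H](O)Cn2cc(-c3cccc(O)c3)nn2)C(OCc2ccccc2)=C1OCc1ccccc1`) gives 51800 nM while compound 2 (`O=C1O[C@H]([C@@H](O)Cn2cc(-c3cc(F)cc(F)c3)nn2)C(OCc2ccccc2)=C1OCc1ccccc1`) gives 27700 nM and compound 3 (`Cc1ccc(S(=O)(=O)NCc2cn(C[C@H](O)[C@H]3OC(=O)C(OCc4ccccc4)=C3OCc3ccccc3)nn2)cc1`) gives 6400 nM as the lowest of the three numbers.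

Compound 4 (`O=C1O[C@H]([C@@H](O)Cn2cc(CCO)nn2)C(OCc2ccccc2)=C1OCc1ccccc1`) is still unmeasured. It carries hydroxymethyl in place of ((4-methylphenyl)sulfonyl)amino on a saturated chain carbon bound to an aromatic carbon.

Swapping one ring-bearing group for the other gives a 1.9-fold lower number from compound 1 to compound 2 (0.27 log units; within the scatter) and so shows no clear change. Compound 3 alone holds the sulfonamide group, and its gains are modest: an 8.1-fold lower number from compound 1 to compound 3 (0.91 log units; beyond the scatter) and a 4.3-fold lower number from compound 2 to compound 3 (0.64 log units; beyond the scatter) in turn. Among the measured compounds shown here, no measured compound carries a group as small as 2-hydroxyethyl, so the forecast is uncertain.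

Losing that group is expected to undo a gain of similar size in this assay and move the number upward. The estimated step is a 3.9-fold higher number from compound 3 to compound 4 (0.59 log units; beyond the scatter) on this reasoning. For compound 4 the expected value is 25000 nM with an estimated range from 9000 nM to 70000 nM in this test.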

Compound 4, half-maximal inhibitory concentration: 63400 nM
Estimate against measurement, compound 4: 2.5-fold (0.40 log units) below; low and high end bracket the measured number.
By their numbers in this assay, from the lowest: compound 3; then compounds 2, 1 and 4 (each within the scatter of the next, the first and the last beyond it).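

The step of a 9.9-fold higher number from compound 3 to compound 4 (1.00 log units; beyond the scatter) shows that on a saturated chain carbon bound to an aromatic carbon, hydroxymethyl does not keep the low number seen with ((4-methylphenyl)sulfonyl)amino in this assay. The ring-free 2-hydroxyethyl group also fails to approach compound 3: the comparisons give a 2.3-fold higher number from compound 2 to compound 4 (0.36 log units; beyond the scatter) and a 1.2-fold higher number from compound 1 to compound 4 (0.09 log units; within the scatter), the latter within the scatter. Compound 3 therefore stands apart from all three other compounds, whether their group on the aromatic carbon carries a ring or not. No supporting data here explain this difference.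

The compounds shown leave open whether the sulfonyl part or the 4-methylphenyl ring accounts for the low number of compound 3. A methylsulfonylamino group or a plain benzoylamino group at the same place would help separate the two.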